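This account rests on a few compounds, and the source may have more. Where it says the series, first, only, none or still open, it means among the compounds named here.

For the measured compounds named here, in an ADME assay on J774 cells (Mus musculus) for cytotoxicity, read by resazurin assay, with a stated time of 72 h (a lower number here means that less compound is tolerated, a higher number that more compound is tolerated), compound 3 (`C/C(=N\Nc1nc(-c2ccccn2)cs1)c1ccc(Cl)c(Cl)c1`) gives 10100 nM, the only true number among the values shown. Compound 1 (`C/C(=N\N=c1\scc(-c2ccccc2)n1C)c1ccc(Cl)c(Cl)c1`) reads > 50000 nM, which is a limit of the assay. Compound 2 (`C/C(=N\N=c1\scc(-c2ccccc2)n1-c1ccccc1)c1ccc(Cl)c(Cl)c1`) reads > 50000 nM, which is also a limit.

The next compound, compound 4 (`C/C(=N\Nc1nc(-c2ccc(Cl)c(Cl)c2)cs1)c1ccc(Cl)c(Cl)c1`), carries 3,4-dichlorophenyl in place of pyridin-2-yl on an aromatic carbon of the five-membered aromatic ring with 1 nitrogen and 1 sulfur: 3,4-dichlorophenyl in place of pyridin-2-yl on an aromatic carbon.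

Going by the values given here, only one measured step exists, a step that the two limits leave unreadable from compound 1 to compound 2. It lies at an aromatic nitrogen rather than at the carbon changed here, and it has no readable size, so it offers no size or direction to carry over. Among the compounds with values here, no measured step bears directly on this change. The expectation therefore starts from compound 3 at 10100 nM and foresees no change in this assay beyond the usual scatter, in either direction, though with wide uncertainty.

The estimated change is a 1.2-fold higher number from compound 3 to compound 4 (0.07 log units; within the scatter). Compound 4 is expected to read about 12000 nM, with an estimated range of 3500 nM to 45000 nM. Compound 4 could also return only a limit, namely (the limit of > 50000 nM in this assay, at which 2 of the 3 values shown sit).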

Compound 4, half-maximal cytotoxic concentration: > 50000 nM
Compound 4: only a limit was reported (the forecaster's own chance of this, stated with the estimate: 30%); at least 4.1-fold (0.61 log units) between middle value and limit.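

In this assay, the place on the aromatic carbon next to the ring nitrogen yields the only readable step among the compounds shown, with 3,4-dichlorophenyl in place of pyridin-2-yl: an at least 4.9-fold higher number from compound 3 to compound 4 (0.69 log units; beyond the scatter). For the compounds shown here, this shows that the tolerated concentration responds to the group at this position by more than the scatter, something the earlier compounds could not show, since their one step, at an aromatic nitrogen, cannot be read. Compound 4 gives a limit and not a number, so the step has a lower bound only, and compound 4 now stands with most of the values shown: the limit of > 50000 nM in this assay, at which 3 of the 4 values shown sit.

As far as these compounds go, it remains open whether the two chlorine atoms or the loss of the ring nitrogen carries the step, a question that a plain phenyl at this position would help to separate. Also open, from the compounds shown here alone, are how an amine or a carboxylic acid on this aromatic ring would read in this assay, and any order among compound 1, compound 2 and compound 4, all of which sit at a limit.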